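N-Methylation of the Amine in Compound 3

The source may hold more compounds than are shown below. What is called first, only, known or untested is meant among the compounds shown, and "the series" means these compounds.

The measured compounds are:
- compound 1, `CC(C(N)=O)c1cc(=O)oc2cc(OCc3ccccc3)ccc12`: 100 nM
- compound 2, `CN(C)C(=O)Cc1cc(=O)oc2cc(OCc3ccccc3)ccc12`: 400 nM
- compound 3, `CNCc1cc(=O)oc2cc(OCc3ccccc3)ccc12`: 28 nM

All three share one core and differ only in the side chain on an aromatic carbon. In an assay for inhibition of Amine oxidase [flavin-containing] B (Rattus norvegicus) (on this read-out lower numbers stand for stronger inhibition and higher numbers for weaker inhibition), compound 3 gives the lowest number of the three: a 3.6-fold lower number from compound 1 to compound 3 (0.55 log units; beyond the scatter) and a 14-fold lower number from compound 2 to compound 3 (1.15 log units; beyond the scatter), both steps beyond the usual scatter. Between the other two, a 4.0-fold higher number from compound 1 to compound 2 (0.60 log units; beyond the scatter).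

Compound 4, `CN(C)Cc1cc(=O)oc2cc(OCc3ccccc3)ccc12`, differs from compound 3 by methyl in place of hydrogen on an amine nitrogen, that is, methylamino becomes dimethylamino on the chain. Among the measured compounds shown here, no measured step shows this exact change on an amine. The closest hint is the step from compound 1 to compound 2, where an amide nitrogen gains two methyls while the chain also changes, and the number rose moderately; yet that concerns an amide, not an amine. The large step from compound 2 to compound 3 shows that the nitrogen-bearing chain itself matters, but says nothing about a single extra methyl.

For the measured compounds named here, with no direct precedent, a small step in this assay is expected, slightly toward weaker inhibition if anything: a 1.8-fold higher number from compound 3 to compound 4 (0.25 log units; within the scatter). Compound 4 is therefore estimated at 50 nM, with a range of 15 nM to 200 nM.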

Compound 4, half-maximal inhibitory concentration: 1800 nM
Compound 4: middle estimate off by 36-fold (1.56 log units), on the low side, and the stated range ends below it.
By their numbers in this assay, from the lowest: compound 3; then compound 1; then compound 2; then compound 4.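

Read in this assay this one added methyl on the amine nitrogen has a large effect (a 64-fold higher number from compound 3 to compound 4 (1.81 log units; beyond the scatter)), which shows that the side chain is sensitive not only to its overall type but also to a single small change at this nitrogen. Compound 4 also ends up with a higher number than the two amide compounds (a 4.5-fold higher number from compound 2 to compound 4 (0.65 log units; beyond the scatter); an 18-fold higher number from compound 1 to compound 4 (1.26 log units; beyond the scatter)), so the advantage over those amides seen with compound 3 is not shared by every amine on this chain, and the second methyl reverses the order. Nothing available explains why so small a change has so large an effect.

On these data alone, what remains open is how the number responds to other groups on this nitrogen: a primary amine, with two hydrogens and no methyl, or an ethylamino group in place of methylamino, could show whether compound 3 sits near a best point or simply on a steep slope. Among the compounds shown here, a longer chain between the amine and the shared core could also show whether the same methyl step remains this large, since only one such pair is available here.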